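Series notes: cytotoxicity on LoVo cells, quinolinone analogues

This account rests on a few compounds, and the source may have more. Where it says the series, first, only, none or still open, it means among the compounds named here.

Measured so far:
compound 1 `COc1ccc2cc(-c3ccccc3)c(O)nc2c1` – 10000 nM
compound 2 `COc1ccc(-c2cc3c(OC)cc(OC)cc3n(C)c2=O)cc1` – 10000 nM

In a functional assay on LoVo cells (Homo sapiens) for cytotoxicity, read by colorimetric assay and MTT assay (on this read-out lower numbers stand for stronger inhibition and higher numbers for weaker inhibition), compound 1 gives 10000 nM. Compound 2 `COc1ccc(-c2cc3c(OC)cc(OC)cc3n(C)c2=O)cc1` differs from compound 1 in several places at once, so no single step between them is counted; in this assay compound 2 gives 10000 nM, which stands level with compound 1 at the digits shown and within the scatter of it. Both values sit at the weak end of the range, and neither compound sets a direction for the series.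

Compound 3 `COC(=O)CCn1c(=O)c(-c2ccc(OC)cc2)cc2c(OC)cc(OC)cc21` is the next analogue and has not yet been measured in this assay. It differs from compound 2 by (methoxycarbonyl)methyl in place of hydrogen on a saturated chain carbon bound to an aromatic nitrogen; cut one bond further out, the same change reads methyl to 2-(methoxycarbonyl)ethyl on the nitrogen of the shared core.

Within the data shown here, no measured pair shows what a change at this site does. With compound 2 at 10000 nM, compound 3 is expected to stay near the same level, the step from compound 2 being estimated as no change at the digits printed from compound 2 to compound 3 (within the scatter), no larger than the scatter in either direction. The estimate for compound 3 in this assay is 10000 nM, with a range from 3000 nM to 30000 nM.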

Compound 3, half-maximal inhibitory concentration: 10000 nM
Estimate against measurement, compound 3: no gap at the digits printed, and the stated range covers the measured number.
By their numbers in this assay, from the lowest: compounds 1, 2 and 3 (each within the scatter of the next).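

Among these compounds, this is the first readable step at this position: in this assay, (methoxycarbonyl)methyl in place of hydrogen on a saturated chain carbon bound to an aromatic nitrogen gives no change at the digits printed from compound 2 to compound 3 (within the scatter) for the shared core. Read one bond further out, as methyl to 2-(methoxycarbonyl)ethyl, the change brings in a chain with no ring, no net charge and no hydrogen-bond donors, yet compound 3 stands level with compound 2, so this one substitution at the aromatic nitrogen gives no separation between the two compounds on this read-out. No data on hand offer an explanation for this result.

One step at one site leaves open whether a different group on this nitrogen, such as a carboxylic acid at the end of the chain, an amine, or a longer chain, would stand apart from compound 2 in this assay. Among the compounds shown here, it also leaves open whether this chain would read the same way with other groups on the rest of the shared core, since only this one pair speaks to the position.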